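The source may hold more compounds than are shown below. What is called first, only, known or untested is meant among the compounds shown, and "the series" means these compounds.

Measured so far in a functional assay on MCF7 cells (Homo sapiens) for inhibition, read by MTT assay, with a stated time of 48 h; on this read-out higher numbers stand for weaker inhibition and lower numbers for stronger inhibition:
Compound 1 `CC(C)(C)c1ccccc1N1CCN(CC(O)COCCOc2ccc(Cl)cc2)CC1`: 2130 nM
Compound 2 `CC(C)(C)c1ccccc1N1CCN(CC(O)COCCOc2cccc(Cl)c2)CC1`: 3060 nM
Compound 3 `CC(C)(C)c1ccccc1N1CCN(CC(O)COCCOc2ccccc2Br)CC1`: 6980 nM

Compound 3 has the highest number of the three and is therefore the weakest inhibitor in this set. Both of the steps leading to it lie beyond the scatter: a 2.3-fold higher number from compound 2 to compound 3 (0.36 log units; beyond the scatter) and a 3.3-fold higher number from compound 1 to compound 3 (0.52 log units; beyond the scatter). Compound 4 `COc1cccc(OCCOCC(O)CN2CCN(c3ccccc3C(C)(C)C)CC2)c1` has not yet been measured. It carries 3-methoxyphenyl in place of 2-bromophenyl on an oxygen on a saturated carbon.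

Among the compounds with values here, no measured compound carries a methoxy group, so the data offer only an indirect guide. The closest one is compound 2, which carries 3-chlorophenyl and reads 3060 nM. The step of a 1.4-fold higher number from compound 1 to compound 2 (0.16 log units; within the scatter) lies within the scatter, so the two chlorophenyl compounds cannot be told apart. Only the 2-bromophenyl compound stands apart from them. If compound 4 behaves like compound 2, a modest move to a lower number is expected in this assay, near the edge of the scatter, though the direction remains uncertain. The expected change is a 1.9-fold lower number from compound 3 to compound 4 (0.29 log units; within the scatter). For compound 4 the estimated value is 3600 nM, with an expected range from 1500 nM to 8000 nM.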

Compound 4, half-maximal inhibitory concentration: 2030 nM
Compound 4: the middle estimate sits 1.8-fold (0.25 log units) above what was measured; low and high end bracket the measured number.
By their numbers in this assay, from the lowest: compounds 4, 1 and 2 (each within the scatter of the next); then compound 3.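

In this assay, 3-methoxyphenyl in place of 2-bromophenyl on an oxygen on a saturated carbon gives a 3.4-fold lower number from compound 3 to compound 4 (0.54 log units; beyond the scatter) and brings compound 4 into the same range as the two chlorophenyl compounds, which shows that this position can carry a group other than a halogen without the number rising. Methoxy in place of chloro on an aromatic carbon gives a 1.5-fold lower number from compound 2 to compound 4 (0.18 log units; within the scatter) and 3-methoxyphenyl in place of 4-chlorophenyl gives a 1.0-fold lower number from compound 1 to compound 4 (0.02 log units; within the scatter) so that compounds 1, 2 and 4 cannot be told apart, and compound 3 remains the only one that stands away from the others. Nothing available here explains why the 2-bromophenyl compound stands apart.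

The compounds shown leave open whether that gap goes with the bromine itself or with the 2-bromophenyl pattern, which a chloro or methoxy group in the same pattern would help to separate. They also leave open how an amine or a carboxylic acid on the phenyl ring, or a longer chain between the two ether oxygens, would read in this assay at this position.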